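The compounds below may be only part of what the source reports. "The series", "measured", "known", "first", "only" and "open" are said of these compounds alone.

Measured compounds:
- Compound 1 `O=C1C=CC(OCC(F)(F)F)N1c1ccccc1` — 23400 nM
- Compound 2 `O=C1C=CC(OCC(F)(F)F)N1c1ccc(Cl)cc1F` — 6630 nM

Both compounds share one core and differ only in the substituents on the phenyl ring. In a functional assay on A549 cells (Homo sapiens) for inhibition (a lower number here means a stronger inhibitor, a higher number a weaker inhibitor), compound 1 gives 23400 nM, while compound 2 gives 6630 nM. Of these two numbers, compound 2 has the lower one, and the gap between compound 2 and compound 1 is beyond the usual scatter of the assay, so compound 2 stands as the stronger inhibitor of the pair.

Compound 3 `O=C1C=CC(OCC(F)(F)F)N1c1ccccc1F` has not yet been measured in this assay. It differs from compound 2 in one place: hydrogen in place of chloro on an aromatic carbon. With the chloro removed, compound 3 sits between compound 1 and compound 2 in its substitution.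

Within the data shown here, no measured step of this exact kind is available. Since compound 1 gives 23400 nM and compound 2 gives 6630 nM, the expectation for compound 3 is a weakening step, estimated as a 2.1-fold higher number from compound 2 to compound 3 (0.32 log units; beyond the scatter). The estimated value for compound 3 is 14000 nM, with a range from 6000 nM to 35000 nM.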

Compound 3, half-maximal inhibitory concentration: 44900 nM
Estimate against measurement, compound 3: 3.2-fold (0.51 log units) below; measured number above the stated range.
By their numbers in this assay, from the lowest: compound 2; then compounds 1 and 3 (each within the scatter of the next).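

In this assay, taking the chloro off compound 2 gives a step of a 6.8-fold higher number from compound 2 to compound 3 (0.83 log units; beyond the scatter) and so a clearly weaker inhibitor, which marks this place on the aromatic ring, para to a large group and meta to a fluoro group, as one that counts in this small set. The fluoro group alone gives no change that can be read, with a 1.9-fold higher number from compound 1 to compound 3 (0.28 log units; within the scatter) as the step, so it does not by itself account for the lower number of compound 2.

Still open, from the compounds shown here alone, is whether a bromo, a methyl or a methoxy group at the same place would serve as well as chloro. Also open, going by these compounds, is what chloro would do on a ring without the fluoro group. No measurement here explains why the chloro matters so much.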